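Bulkier chain ends on a histamine receptor agonist

The source may hold more compounds than are shown below. What is called first, only, known or untested is meant among the compounds shown, and "the series" means these compounds.

Compound 1 `CCCNC(=O)/N=C(\N)NCCCc1sc(N)nc1C` is measured in a functional assay on HEK293T cells for agonist activity at histamine H2 receptor (Homo sapiens), read by beta-arrestin recruitment (on this read-out higher numbers stand for an effect only at larger amounts of compound and lower numbers for an effect already at smaller amounts), where compound 1 gives 170 nM, the highest of the two numbers seen. Compound 2 `CCCCCCNC(=O)/N=C(\N)NCCCc1sc(N)nc1C` gives 85.1 nM; the step of a 2.0-fold lower number from compound 1 to compound 2 (0.30 log units; within the scatter) comes from adding propyl to the chain. Compound 3 `Cc1ccc(CC(C)CNC(=O)/N=C(\N)NCCCc2sc(N)nc2C)cc1` carries 4-methylbenzyl in place of hydrogen on a saturated chain carbon bound to two saturated chain carbons. Among the measured compounds shown here, the only step bearing on it, from compound 1 to compound 2, was small, so a similarly modest lowering or no clear change is expected here. The expected step of a 2.0-fold lower number from compound 1 to compound 3 (0.30 log units; within the scatter) rests on that. Compound 3 is therefore estimated at 85 nM, with a range from 25 nM to 280 nM.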

Compound 3, half-maximal effective concentration: 132 nM
Compound 3: middle estimate off by 1.6-fold (0.19 log units), on the low side; the measured number falls inside the stated range.
By their numbers in this assay, from the lowest: compounds 2, 3 and 1 (each within the scatter of the next).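

In this assay, the step of a 1.3-fold lower number from compound 1 to compound 3 (0.11 log units; within the scatter) shows that this position accepts more than a plain chain. The earlier step added only propyl, whereas 4-methylbenzyl brings 8 heavy atoms and a six-membered aromatic ring to a saturated chain carbon bound to two saturated chain carbons, and the number stays within the scatter. From the compounds shown here alone, whether an amine or a carboxylic acid on this same carbon would also leave the number within the scatter remains open. No measurement shown gives a reason for this result.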